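This account rests on a few compounds, and the source may have more. Where it says the series, first, only, none or still open, it means among the compounds named here.

In a functional assay on MGC-803 cells (Homo sapiens) for antiproliferative activity, read by MTT assay, with a stated time of 72 h (on this read-out lower numbers stand for stronger inhibition and higher numbers for weaker inhibition), compound 1 `C/C(=N\NC(=O)c1cccc(S(=O)(=O)N2CCOCC2)c1)c1cccc(N)c1O` gives 530 nM. Compound 2 `O=C(N/N=C/c1ccco1)c1cccc(S(=O)(=O)N2CCOCC2)c1` reads > 100000 nM, which is a limit of the assay and not a number. Compound 3 `O=C(N/N=C/c1cc(Cl)ccc1O)c1cccc(S(=O)(=O)N2CCOCC2)c1` differs from compound 2 by 5-chloro-2-hydroxyphenyl in place of furan-2-yl on a carbon with a double bond to nitrogen, with 5-chloro-2-hydroxyphenyl in place of furan-2-yl on a carbon with a double bond to nitrogen. Among the compounds with values here, no measured step covers this change. Compound 1 also carries a hydroxyl-bearing phenyl on that carbon and gives 530 nM, so a large move toward lower numbers in this assay is expected. The expected step is an at least 40-fold lower number from compound 2 to compound 3 (1.60 log units; beyond the scatter). Compound 3 is estimated at 2500 nM, with an expected range of 400 nM to 20000 nM.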

Compound 3, half-maximal inhibitory concentration: 11000 nM
For compound 3 the middle estimate is 4.4-fold (0.64 log units) below the measured one, and the stated range covers the measured number.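

In this assay the carbon with a double bond to nitrogen proves sensitive to the group it carries: 5-chloro-2-hydroxyphenyl in place of furan-2-yl gives an at least 9.0-fold lower number from compound 2 to compound 3 (0.95 log units; beyond the scatter) in this series. Compound 2 reads > 100000 nM as a limit of the assay and not a number. Only a lower bound on the step is known, and its true size stays unfixed: the limit of > 100000 nM in this assay, at which 1 of the 3 values shown sits.

Still open, going by these compounds, is whether the hydroxyl or the chlorine carries the step. Also open, on these data alone, is how a methoxy group in place of the hydroxyl, or a bromine in place of the chlorine, would read.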